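The source may report more compounds than this note shows. Statements on the series, on what has been measured and on what is new or still open speak of the compounds shown alone.

Compound 1 `Cc1ccc(NC2=CC(=O)c3c(nc4n3[C@H]3OC[C@@H](O)[C@H]3OC4)C2=O)cc1C`: 1050 nM
Compound 2 `O=C1C=C(NCc2ccccc2)C(=O)c2c1nc1n2[C@H]2OC[C@@H](O)[C@H]2OC1`: 2670 nM
Compound 3 `O=C1C=C(N2CCCCC2)C(=O)c2c1nc1n2[C@H]2OC[C@@H](O)[C@H]2OC1`: > 8000 nM

The account follows the step from compound 1 to compound 4. In a functional assay on MGC-803 cells (Homo sapiens) for inhibition, read by sulforhodamine B assay (a lower number here means a stronger inhibitor, a higher number a weaker inhibitor), compound 1 holds the lowest of the two numbers given, and compound 2 sits at a higher number, beyond the scatter. For compound 3 this assay gives only a limit, (the limit of > 8000 nM in this assay, at which 1 of the 3 values shown sits), and not a number.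

Compound 4 `O=C1C(N2CCC2)=CC(=O)c2c1nc1n2[C@H]2OC[C@@H](O)[C@H]2OC1` has not been measured in this assay. It differs from compound 1 by azetidin-1-yl in place of (3,4-dimethylphenyl)amino on a double-bonded ring carbon. For the measured compounds named here, one measured step bears on this change: the move from a benzylamino group to a cyclic amine on the same kind of ring carbon, which gave an at least 2.9-fold higher number from compound 2 to compound 3 (0.47 log units; beyond the scatter). Compound 4 makes a move of the same type from the shared core of compound 1, replacing an aryl amino group with a small cyclic amine, so a rise in the number beyond the scatter is expected in this assay, although the step is measured only once and only as a limit.

Compound 4 is therefore estimated to reach 5000 nM, within 2000 nM to 12000 nM, which would mean an expected step of a 4.8-fold higher number from compound 1 to compound 4 (0.68 log units; beyond the scatter).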

Compound 4, half-maximal inhibitory concentration: > 16000 nM
Compound 4 ended at the assay's limit; the forecaster's own chance of this, stated with the estimate: 35%; middle value at least 3.2-fold (0.50 log units) from the limit.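

In this assay, for the compounds shown here, azetidin-1-yl in place of (3,4-dimethylphenyl)amino on a double-bonded ring carbon gives an at least 15-fold higher number from compound 1 to compound 4 (1.18 log units; beyond the scatter), a large step, where the earlier compounds offered only an at least 2.9-fold higher number from compound 2 to compound 3 (0.47 log units; beyond the scatter). Both steps now run the same way, with a cyclic amine replacing an amino group that carries an aromatic ring and the number rising, and no compound shown goes against this, so the rise is not tied to the piperidin-1-yl ring alone. The full size of the new step cannot be given, because compound 4 gives no number in this assay, only a limit: the limit of > 16000 nM in this assay, at which 1 of the 4 values shown sits.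

Compound 3 and compound 4 both stand at limits, so the four-membered and six-membered cyclic amines cannot be ranked against each other. As far as these compounds go, the change to compound 4 removes the amine hydrogen and the aromatic ring together, and it stays open which of them matters; a cyclohexylamino group, which keeps the hydrogen without the aromatic ring, or a methyl(3,4-dimethylphenyl)amino group, which keeps the aromatic ring without the hydrogen, would separate the two.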